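The compounds below may be only part of what the source reports. "The series", "measured", "known", "first", "only" and "open" are said of these compounds alone.

Of the compounds shown here, three on a shared core have been measured in a functional assay on HepG2 cells (Homo sapiens) for inhibition, read by MTT assay; on this read-out higher numbers stand for weaker inhibition and lower numbers for stronger inhibition. Compound 1 `COc1cc2ncnc(Nc3ccc(NC(=O)c4cccc(C)c4)cc3)c2cc1OC` gives 7500 nM, compound 2 `COc1cc2ncnc(Nc3ccc(NC(=O)c4ccccc4Cl)cc3)c2cc1OC` gives 26000 nM, and compound 3 `COc1cc2ncnc(Nc3ccc(NC(=O)c4c(F)cccc4F)cc3)c2cc1OC` gives 17000 nM. Compound 2 stands at the highest of the three numbers: the step of a 3.5-fold higher number from compound 1 to compound 2 (0.54 log units; beyond the scatter) lies beyond the scatter, whereas a 1.5-fold lower number from compound 2 to compound 3 (0.18 log units; within the scatter) lies within it. Compound 4 `COc1cc2ncnc(Nc3ccc(NC(=O)c4ccc(Cl)c(Cl)c4)cc3)c2cc1OC` is not yet measured; it differs from compound 2 by 3,4-dichlorophenyl in place of 2-chlorophenyl on a carbonyl carbon. Going by the values given here, no measured step carries the 3,4-dichlorophenyl. The changes on this aryl seen so far, a 3.5-fold higher number from compound 1 to compound 2 (0.54 log units; beyond the scatter) and a 2.3-fold higher number from compound 1 to compound 3 (0.36 log units; beyond the scatter), were modest, so only a modest step in this assay, in either direction, is expected. The number for compound 4 is estimated at 12000 nM, range 3500 nM to 40000 nM. This means an expected step of a 2.2-fold lower number from compound 2 to compound 4 (0.34 log units; beyond the scatter).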

Compound 4, half-maximal inhibitory concentration: 28000 nM
Estimate against measurement, compound 4: 2.3-fold (0.37 log units) below; the measured number falls inside the stated range.
By their numbers in this assay, from the lowest: compound 1; then compounds 3, 2 and 4 (each within the scatter of the next).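

In this assay, 3,4-dichlorophenyl on the carbonyl carbon sits level with the earlier halogenated aryls (a 1.1-fold higher number from compound 2 to compound 4 (0.03 log units; within the scatter); a 1.6-fold higher number from compound 3 to compound 4 (0.22 log units; within the scatter)), so the higher numbers are not confined to the 2-chlorophenyl and 2,6-difluorophenyl groups. The 3-methylphenyl of compound 1 remains apart from all three halogenated aryls, now including the new one (a 3.7-fold higher number from compound 1 to compound 4 (0.57 log units; beyond the scatter)). Nothing at hand accounts for this result. Still open, going by these compounds, is whether a methyl group alone underlies the lower number of compound 1, and whether an aryl carrying an amine or a carboxylic acid would extend the range.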